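The compounds below may be only part of what the source reports. "The series", "measured", "known", "first", "only" and "open" are said of these compounds alone.

Compound 1 `O=C1NC(=O)/C(=C/C2=Cc3cc(Br)ccc3OC2)S1` is the starting point: in a functional assay on MCF7 cells (Homo sapiens) for antiproliferative activity, read by MTT assay, with a stated time of 72 h (on this read-out lower numbers stand for stronger inhibition and higher numbers for weaker inhibition), compound 1 gives 57900 nM. Compound 2 `O=C1NC(=O)/C(=C/C2=Cc3cc(Br)ccc3OC2)N1` shares much of its make-up with compound 1 but has a different core; how the two cores differ is not broken down here. In this assay compound 2 gives 51000 nM. Compound 3 `CC1Oc2ccc(Br)cc2C=C1/C=C1\SC(=O)NC1=O` differs from compound 1 by methyl in place of hydrogen on a saturated ring carbon, and in this assay compound 3 gives 67600 nM, which is a 1.2-fold higher number from compound 1 to compound 3 (0.07 log units; within the scatter). Compound 4 `CC1Oc2ccc(Br)cc2C=C1/C=C1\NC(=O)NC1=O` differs from compound 2 by methyl in place of hydrogen on a saturated ring carbon, the same change at the same place. Because a 1.2-fold higher number from compound 1 to compound 3 (0.07 log units; within the scatter) stayed within the usual scatter, the step from compound 2 to compound 4 is expected to be similar, namely a 1.2-fold higher number from compound 2 to compound 4 (0.07 log units; within the scatter). On that basis compound 4 is expected to give about 60000 nM in this assay, most likely between 30000 nM and 120000 nM.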

Compound 4, half-maximal inhibitory concentration: 15300 nM
The estimate for compound 4 lay 3.9-fold (0.59 log units) above the measured number; the whole stated range lies above it.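

Putting methyl in place of hydrogen on the saturated ring carbon gives a 3.3-fold lower number from compound 2 to compound 4 (0.52 log units; beyond the scatter) in this assay and so makes a modest difference on this core. The same change did not carry over evenly between the two cores: the same change on two cores in this assay, a 1.2-fold higher number (0.07 log units; within the scatter) from compound 1 to compound 3 and a 3.3-fold lower number (0.52 log units; beyond the scatter) from compound 2 to compound 4, 3.9-fold (0.59 log units) apart, beyond the scatter of two such steps. This shows that a step read on one core cannot simply be copied onto the other in this series, but it does not show why the cores differ, and two pairs give no rule for any further core.

As far as these compounds go, whether an ethyl group or an amine on that same ring carbon would behave alike on both cores stays open. So does whether the lower number of compound 4 would hold in other cell lines.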